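Methylamino in place of ethylamino on the shared core

The source may hold more compounds than are shown below. What is called first, only, known or untested is meant among the compounds shown, and "the series" means these compounds.

Measured so far:
- compound 1 `CCNc1nnc(-c2cc(-c3ccc(F)cc3F)ccc2O)s1` gives 50.2%
- compound 2 `Oc1ccc(-c2ccc(F)cc2F)cc1-c1n[nH]c(=S)n1C1CCCCC1` gives 64.4%

Two compounds have been run in a functional assay on the whole organism (strain BALB/c) for inhibition, with Mus musculus as the target, read by paw edema, with a stated time of 4 h, at a dose of 50 mg/kg by the oral route; on this read-out higher numbers stand for more inhibition at the one dose given (going by the name of the read-out) and lower numbers for less inhibition. Compound 1 gives 50.2% and stands lowest of the two numbers; compound 2 gives 64.4%, a reading higher than that of compound 1 by a gap beyond the usual scatter. Among the measured compounds shown here, compound 1 and compound 2 differ in more than one place, so no single-point step between measured compounds is available, and nothing measured yet shows what trimming the side chain does.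

Compound 3 `CNc1nnc(-c2cc(-c3ccc(F)cc3F)ccc2O)s1` is the next one to be measured in this assay. It differs from compound 1 in one place: hydrogen in place of methyl on a saturated chain carbon bound to a nitrogen on an aromatic ring. The change is the smallest one possible on that chain, and no shown step gives a direction for it. The step from compound 1 to compound 3 is therefore expected to be small, a number 2.2 percentage points lower from compound 1 to compound 3 (within the scatter), not beyond the scatter in either direction. Compound 3 is expected to give 48% in this assay, with a range from 34% to 62%.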

Compound 3, a percentage reported as inhibition, in the whole organism at one dose (the size of the read-out at that dose, not a potency): 45.4%
For compound 3 the middle estimate is 2.6 percentage points above the measured one; the measured number falls inside the stated range.
By their numbers in this assay, from the lowest: compounds 3 and 1 (each within the scatter of the next); then compound 2.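

Among the compounds shown here, the first single-place step, read in this assay, is a number 4.8 percentage points lower from compound 1 to compound 3 (within the scatter), so at this one dose and time the read-out does not separate ethylamino from methylamino on the shared core. Replacing methyl with hydrogen on a saturated chain carbon bound to a nitrogen on an aromatic ring therefore has no effect that can be told from the scatter, a point that the earlier pair could not address because its members differ in more than one place. No supporting data bear on why this change leaves the reading within the scatter.

On these data alone, the two chain lengths cover only a short stretch of this position, so it remains open whether a longer chain such as n-propyl or n-butyl, a branched group such as isopropyl, or the plain amino group would give a step beyond the scatter. Also open, as far as these compounds go, is whether the same change would read alike at other doses or times, since a single dose gives the size of the read-out there and not a potency.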